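Swapping a bromophenyl for a furan on the shared core

The source may report more compounds than this note shows. Statements on the series, on what has been measured and on what is new or still open speak of the compounds shown alone.

Measured so far:
compound 1 `O=C1C(=Cc2ccc(Br)cc2)C(=O)N(c2ccc(Cl)cc2)N1c1ccc(Cl)cc1`: 30400 nM
compound 2 `COc1cccc(C=C2C(=O)N(c3ccc(Cl)cc3)N(c3ccc(Cl)cc3)C2=O)c1O`: 26700 nM
compound 3 `O=C1C(=Cc2ccc(Cl)cc2Cl)C(=O)N(c2ccc(Cl)cc2)N1c1ccc(Cl)cc1`: > 128000 nM (a limit)

In a functional assay on MCF7 cells (Homo sapiens) for cytotoxicity, read by MTT assay, with a stated time of 72 h (a lower number here means a stronger inhibitor, a higher number a weaker inhibitor), compound 1 gives 30400 nM, the higher of the two plain numbers, yet compound 2 sits within the scatter of it, as a 1.1-fold lower number from compound 1 to compound 2 (0.06 log units; within the scatter). Compound 3 reached only a limit of the assay, > 128000 nM. Compound 4 `O=C1C(=Cc2ccco2)C(=O)N(c2ccc(Cl)cc2)N1c1ccc(Cl)cc1` differs from compound 1 by furan-2-yl in place of 4-bromophenyl on a double-bonded chain carbon bound to a double-bonded ring carbon. Among the measured compounds shown here, no measured step makes this change. Changing the same group gave either no shift, a 1.1-fold lower number from compound 1 to compound 2 (0.06 log units; within the scatter), or a weakening, an at least 4.2-fold higher number from compound 1 to compound 3 (0.62 log units; beyond the scatter), with the limit of > 128000 nM in this assay, at which 1 of the 3 values shown sits, marking that edge. A small weakening is therefore expected for compound 4, a 1.5-fold higher number from compound 1 to compound 4 (0.17 log units; within the scatter). Compound 4 is estimated at 45000 nM, within 15000 nM to 128000 nM.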

Compound 4, half-maximal inhibitory concentration: 20300 nM
Estimate against measurement, compound 4: 2.2-fold (0.35 log units) above; the range from low to high includes it.
By their numbers in this assay, from the lowest: compounds 4, 2 and 1 (each within the scatter of the next). At a limit, above all of these: compound 3.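

In this assay, furan-2-yl, a five-membered aromatic ring, is tolerated on a double-bonded chain carbon bound to a double-bonded ring carbon, giving a 1.5-fold lower number from compound 1 to compound 4 (0.18 log units; within the scatter) and a 1.3-fold lower number from compound 2 to compound 4 (0.12 log units; within the scatter). The position therefore accepts a ring with fewer heavy atoms than 4-bromophenyl without a change beyond the scatter. Only 2,4-dichlorophenyl stands apart, with an at least 6.3-fold lower number from compound 3 to compound 4 (0.79 log units; beyond the scatter), and that step is read from a limit of the assay: the limit of > 128000 nM in this assay, at which 1 of the 4 values shown sits.

Going by these compounds, all four groups here are aromatic rings, so the effect of an amine, a carboxylic acid or a longer chain at this position remains open.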